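Swapping hydroxy for methyl beside a nitro-bearing half

A few compounds are considered here, and "the series" means these few. Any claim that something is new, unique, unknown or untested is made for them only; others in the source may bear on it.

In a functional assay on U-87MG ATCC cells (Homo sapiens) for cytotoxicity, read by resazurin assay, with a stated time of 48 h (on this read-out lower numbers stand for stronger inhibition and higher numbers for weaker inhibition), compound 1 (`O=C1/C(=C/c2ccc(O)cc2)CS(=O)(=O)C/C1=C\c1ccc(O)cc1`) gives 6730 nM, compound 2 (`COc1ccc(/C=C2\CS(=O)(=O)C/C(=C\c3ccc(OC)c([N+](=O)[O-])c3)C2=O)cc1[N+](=O)[O-]`) gives 1140 nM and compound 3 (`O=C1/C(=C/c2ccc(O)cc2)CS(=O)(=O)C/C1=C\c1ccc([N+](=O)[O-])cc1`) gives 2170 nM. Compound 3 thus sits within the scatter of compound 2 and clearly under compound 1. Compound 4 (`Cc1ccc(/C=C2\CS(=O)(=O)C/C(=C\c3ccc([N+](=O)[O-])cc3)C2=O)cc1`) carries methyl in place of the hydroxy of compound 3: methyl in place of hydroxy on an aromatic carbon. Among the compounds with values here, one measured step bears on this, hydroxy replaced by nitro, with a 3.1-fold lower number from compound 1 to compound 3 (0.49 log units; beyond the scatter). That step also removes a hydroxy but brings in a different group, so it is only a loose guide. A small fall in this assay is expected, possibly none beyond the scatter. For compound 4 the estimated value is 1500 nM, within a range of 550 nM to 4000 nM. This would be an expected 1.4-fold lower number from compound 3 to compound 4 (0.16 log units; within the scatter).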

Compound 4, half-maximal inhibitory concentration: 1390 nM
Compound 4: middle estimate off by 1.1-fold (0.03 log units), on the high side; measured number inside the range.
By their numbers in this assay, from the lowest: compounds 2, 4 and 3 (each within the scatter of the next); then compound 1.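

In this assay the swap gives a 1.6-fold lower number from compound 3 to compound 4 (0.19 log units; within the scatter), so the hydroxy, with the hydrogen-bond donor and acceptor counted for it, is not needed at this position to keep the number within the scatter, at least in a compound with this nitro-bearing half. Methyl, which has neither, serves as well here. Nothing available explains this result. From the compounds shown here alone, whether an amine or a carboxylic acid at the same position would also leave the number within the scatter remains open. So does whether methyl would do the same opposite a half without nitro.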